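Methyl in place of hydrogen on compound 2

The source may report more compounds than this note shows. Statements on the series, on what has been measured and on what is new or still open speak of the compounds shown alone.

- compound 1 `CCn1c(C(=O)N[C@@H](C)C(=O)OC)ccc1C(CC)(CC)c1ccc(OCS(=O)(=O)c2ccccc2)c(C)c1`: 17900 nM
- compound 2 `CCn1c(C(=O)NCC(=O)OC)ccc1C(CC)(CC)c1ccc(OCS(=O)(=O)c2ccccc2)c(C)c1`: 20000 nM
- compound 3 `CCn1c(C(=O)N[C@H](C)C(=O)OC)ccc1C(CC)(CC)c1ccc(OCS(=O)(=O)c2ccccc2)c(C)c1`: not yet measured

These compounds were tested in a functional assay on BXPC-3 cells (Homo sapiens) for antiproliferative activity, read by MTT assay, with a stated time of 24 h; a higher number here means a weaker inhibitor, a lower number a stronger inhibitor. Within the data shown here, only two numbers are available so far. Compound 2, at 20000 nM, lies within the usual scatter of compound 1, at 17900 nM, so neither can be ranked above the other.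

Compound 3 keeps the core of compound 2 and changes one place: methyl in place of hydrogen on a saturated chain carbon bound to an amide-type nitrogen and a carbonyl carbon. The methyl sits on a saturated chain carbon bound to an amide-type nitrogen and a carbonyl carbon, turning (methoxycarbonyl)methyl into 1-(methoxycarbonyl)ethyl.

Among the measured compounds shown here, one measured step bears on this change. It runs the opposite way, hydrogen in place of methyl at that same place: a 1.1-fold higher number from compound 1 to compound 2 (0.05 log units; within the scatter). For the measured compounds named here, that step stayed within the scatter, and it is the only evidence available, so no shift beyond the scatter is expected in this assay. The estimated step is a 1.1-fold lower number from compound 2 to compound 3 (0.02 log units; within the scatter), and no direction can be expected with any confidence. The estimate for compound 3 is 19000 nM, with an expected range from 10000 nM to 36000 nM.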

Compound 3, half-maximal inhibitory concentration: > 50000 nM
Compound 3 gave a limit, no number (the forecaster's own chance of this, stated with the estimate: 10%); middle value at least 2.6-fold (0.42 log units) from the limit.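

In this assay compound 3 gave a limit and not a number: the limit of > 50000 nM in this assay, at which 1 of the 3 values shown sits. The methyl on a saturated chain carbon bound to an amide-type nitrogen and a carbonyl carbon can therefore matter at this position, which the earlier pair did not show: the result is an at least 2.5-fold higher number from compound 2 to compound 3 (0.39 log units; beyond the scatter), whereas the earlier comparison gave a 1.1-fold higher number from compound 1 to compound 2 (0.05 log units; within the scatter). The outcome of this change differs with the configuration of the new stereocentre, since the comparison of the two methyl-bearing compounds gives an at least 2.7-fold higher number from compound 1 to compound 3 (0.44 log units; beyond the scatter), and that gap goes with a single structural difference: the fact that compounds 1 and 3 differ only in the configuration as drawn.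

Going by these compounds, the size of both new steps stays open, as the limit for compound 3 fixes only one end of each. On these data alone, it also remains open whether a longer chain such as ethyl at this carbon, or a carboxylic acid in place of the methyl ester, would show the same dependence on configuration in this cell assay.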